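From trifluoromethyl to pyridin-3-yl in compound 4

The compounds below may be only part of what the source reports. "The series", "measured", "known", "first", "only" and "open" are said of these compounds alone.

Compound 1 `CNC(=O)[C@@H]1CCCN1S(=O)(=O)c1ccc(Cl)c(COc2cccc3c(C(F)(F)F)cc(C)nc23)c1Cl` is the reference here, measured in an ADME assay on microsomes (Homo sapiens) for metabolic stability; on this read-out lower numbers stand for slow clearance and higher numbers for fast clearance. In that read-out compound 1 gives 250 mL/min/kg, level with compound 2 `Cc1cc(C(F)(F)F)c2cccc(OCc3c(Cl)ccc(S(=O)(=O)N4CCC[C@H]4CO)c3Cl)c2n1` at 250 mL/min/kg, while compound 3 `Cc1cc(C(F)(F)F)c2cccc(OCc3c(Cl)ccc(S(=O)(=O)N4CCC(CCO)CC4)c3Cl)c2n1` gives 367 mL/min/kg. These three numbers lie within the usual scatter of one another.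

Compound 4 `CNC(=O)[C@@H]1CCCN1S(=O)(=O)c1ccc(Cl)c(COc2cccc3c(-c4cccnc4)cc(C)nc23)c1Cl` keeps the group on the sulfonyl sulfur of compound 1 and alters a different part of the molecule: pyridin-3-yl in place of trifluoromethyl on an aromatic carbon. Pyridin-3-yl stands in place of trifluoromethyl on an aromatic carbon, opposite the ring nitrogen.

Among the measured compounds shown here, all the measured steps concern the group on the sulfonyl sulfur: no change at the digits printed from compound 1 to compound 2 (within the scatter), a 1.5-fold higher number from compound 1 to compound 3 (0.17 log units; within the scatter) and a 1.5-fold higher number from compound 2 to compound 3 (0.17 log units; within the scatter). None of them touches the trifluoromethyl, so the data offer no direct measure of this swap. For the measured compounds named here, they show only that three different sulfonyl groups produced no step beyond the scatter in this assay, on a shared core that carries trifluoromethyl throughout. With nothing pointing either way, no step beyond the scatter is expected, and the uncertainty stays wide. The expected outcome is a 1.1-fold lower number from compound 1 to compound 4 (0.06 log units; within the scatter). Compound 4 is estimated at 220 mL/min/kg, with an expected range from 110 mL/min/kg to 420 mL/min/kg.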

Compound 4, clearance: 233 mL/min/kg
Estimate against measurement, compound 4: 1.1-fold (0.02 log units) below; the range from low to high includes it.
By their numbers in this assay, from the lowest: compounds 4, 1, 2 and 3 (each within the scatter of the next).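

Among the compounds shown here, compounds 1, 2 and 3 all carry trifluoromethyl and differ only in the group on the sulfonyl sulfur, so compound 4 gives the first reading at the position opposite the ring nitrogen: in this assay, pyridin-3-yl in place of trifluoromethyl gives a 1.1-fold lower number from compound 1 to compound 4 (0.03 log units; within the scatter). On the core of compound 1, this position therefore takes an aromatic ring of 6 heavy atoms with 1 hydrogen-bond acceptor, in place of a group of 4 heavy atoms with no ring and no acceptor, without a step beyond the scatter, so this swap does not shift the clearance read-out in either direction. No measurement at hand explains why the number holds through so large a change in structure.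

A single swap cannot show whether this position is insensitive in general, and a phenyl ring, a nitrile or an amine in the same place could still give a step beyond the scatter. On these data alone, it also remains open whether pyridin-3-yl would behave the same way with 2-(hydroxymethyl)pyrrolidin-1-yl or 4-(2-hydroxyethyl)piperidin-1-yl on the sulfonyl sulfur.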